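The source may hold more compounds than are shown below. What is called first, only, known or untested is meant among the compounds shown, and "the series" means these compounds.

In a functional assay on HT-29 cells (Homo sapiens) for inhibition, read by MTT assay, with a stated time of 72 h (a lower number here means a stronger inhibitor, a higher number a weaker inhibitor), the measured compounds stand as follows:

compound 1 `CNCc1c(OC)cc(Oc2cccc(Nc3ccccc3)c2)cc1OC`: 7430 nM
compound 2 `COc1ccc(CCCNCc2c(OC)cc(Oc3cccc(Nc4ccccc4)c3)cc2OC)cc1`: 3320 nM
compound 3 `COc1cc(Oc2cccc(Nc3ccccc3)c2)cc(OC)c1CNC(C)C`: a limit of the assay, > 20000 nM

Compound 3 holds the weakest position among the three: its value is a limit and not a number, the limit being (the limit of > 20000 nM in this assay, at which 1 of the 3 values shown sits). Its two steps from the measured compounds both run upward: an at least 2.6-fold higher number from compound 1 to compound 3 (0.43 log units; beyond the scatter) and an at least 6.0-fold higher number from compound 2 to compound 3 (0.77 log units; beyond the scatter). Compound 2 sits at the strong end, with a 2.2-fold lower number from compound 1 to compound 2 (0.35 log units; beyond the scatter).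

Compound 4 `COc1cc(Oc2cccc(Nc3ccccc3)c2)cc(OC)c1CN(C)C` has not yet been measured. Against compound 3 it reads (dimethylamino in place of isopropylamino on a saturated chain carbon bound to an aromatic carbon). Among the compounds with values here, the step that bears on it most directly is the one from compound 1 to compound 3, where isopropyl in place of methyl on the amine nitrogen pushed the number past the limit; compound 4 returns to methyl on that nitrogen, but as dimethylamino, which removes the donor, a change for which no measured pair exists here. On this basis a downward step is expected, an at least 1.8-fold lower number from compound 3 to compound 4 (0.25 log units; that floor lies within the scatter), with compound 4 estimated at 11000 nM, ranging from 3500 nM to 30000 nM, and a real chance that the assay again reports only a limit.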

Compound 4, half-maximal inhibitory concentration: > 20000 nM
Compound 4 ended at the assay's limit (the forecaster's own chance of this, stated with the estimate: 35%); middle value at least 1.8-fold (0.25 log units) away from the limit.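

In this assay, a single added methyl on the amine nitrogen of compound 1 already costs the measurable value, with an at least 2.6-fold higher number from compound 1 to compound 4 (0.43 log units; beyond the scatter), so the loss on this nitrogen is not peculiar to isopropyl. Replacing (3-(4-methoxyphenyl)propyl)amino with dimethylamino gives an at least 6.0-fold higher number from compound 2 to compound 4 (0.77 log units; beyond the scatter), and the hydrogen-bond donor count does not sort the series on its own: compound 3 keeps the donor and compound 4 has none, yet neither returns a number. Compound 3 and compound 4 each stand at a limit of the assay, so the step between them cannot be read: the limit of > 20000 nM in this assay, at which 2 of the 4 values shown sit.

Still open, on these data alone, is how much of the position of compound 2 comes from the 4-methoxyphenyl group and how much from the chain alone, a question that an unbranched ethyl or propyl group on the nitrogen, or a 3-phenylpropyl chain, would address. Also open, as far as these compounds go, is whether the amine nitrogen accepts a second substituent at all when it is part of a pyrrolidine or carries a longer chain.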